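The compounds below may be only part of what the source reports. "The series", "measured", "known", "first", "only" and "open" are said of these compounds alone.

The series shares one core, seen in compound 1 `O=C(Nc1ccccc1)c1ccc(/N=N\c2c[nH]c3ccccc23)cc1`, compound 2 `Cc1ccc(NC(=O)c2ccc(/N=N\c3c[nH]c4ccccc34)cc2)cc1` and compound 3 `O=C(Nc1ccccc1[N+](=O)[O-])c1ccc(/N=N\c2c[nH]c3ccccc23)cc1`. In a functional assay on P388 cells (Mus musculus) for inhibition, read by MTT assay, with a stated time of 72 h (on this read-out higher numbers stand for weaker inhibition and lower numbers for stronger inhibition), compound 1 gives "not active" (no number reported), with no number reported. In this assay, among the compounds with values here, compound 2 gives 300 nM, while compound 3 gives 77900 nM, the highest of the two numbers known; the step of a 260-fold higher number from compound 2 to compound 3 (2.41 log units; beyond the scatter) lies beyond the scatter. Compound 4 `Cc1ccccc1NC(=O)c1ccc(/N=N\c2c[nH]c3ccccc23)cc1` has not yet been measured. It differs from compound 3 by methyl in place of nitro on an aromatic carbon. Within the data shown here, only one measured step bears on this change, and it sets a 4-methylphenyl against a 2-nitrophenyl rather than a 2-methylphenyl; compound 1, which carries a plain phenyl, gave no number at all, so the weight of a methyl on its own remains uncertain. Given the large step of a 260-fold higher number from compound 2 to compound 3 (2.41 log units; beyond the scatter), a lower number is expected for compound 4, amounting to a 26-fold lower number from compound 3 to compound 4 (1.41 log units; beyond the scatter). The estimate for compound 4 in this assay is 3000 nM, within a range from 300 nM to 40000 nM.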

Compound 4, half-maximal inhibitory concentration: "not active" (no number reported)
Compound 4 has no reported number here; there is nothing to compare the estimate with.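

In this assay, within the data shown here, compound 4 gives "not active" (no number reported) and so leaves no step from compound 3 to compound 4 to be read. The compounds shown leave open how 2-methylphenyl compares with 2-nitrophenyl on this read-out, and nothing shown accounts for the result.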